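From cyano to methoxycarbonyl at the assay limit

The source may hold more compounds than are shown below. What is called first, only, known or untested is meant among the compounds shown, and "the series" means these compounds.

Compound 1 `CCC1=C(C(=O)OCC2CCCCC2)C(c2ccc(N)cc2)NC(=O)N1` and compound 2 `CCC1=C(C(=O)OCC2CCCCC2)C(c2ccc(C#N)cc2)NC(=O)N1` share one core and differ only on an aromatic carbon, where cyano stands in place of amino. In an ADME assay on CEMx174 cells (Homo sapiens) for cytotoxicity (on this read-out lower numbers stand for higher toxicity in this test and higher numbers for lower toxicity in this test), compound 1 gives > 10000 nM, which is a limit of the assay. In this assay compound 2 gives > 10000 nM, again a limit and not a number. Compound 2 thus stands at the limit of > 10000 nM in this assay, at which 2 of the 2 values shown sit. Compound 3 `CCC1=C(C(=O)OCC2CCCCC2)C(c2ccc(C(=O)OC)cc2)NC(=O)N1`, not yet measured, differs from compound 2 by one swap: methoxycarbonyl in place of cyano on an aromatic carbon. Going by the values given here, only one measured step bears on this swap, a step that the two limits leave unreadable from compound 1 to compound 2, and it offers no size to carry over. No step beyond the scatter is therefore expected in this assay, in either direction. The estimated step is a step that the limit leaves unreadable from compound 2 to compound 3. Compound 3 is expected at 20000 nM, with an estimated range from 8000 nM to 50000 nM.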

Compound 3, half-maximal cytotoxic concentration: > 10000 nM
Compound 3 gave a limit, no number (the forecaster's own chance of this, stated with the estimate: 85%); the middle value does not contradict the limit.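

Compound 3, like compound 1 and compound 2, stands only at a limit in this assay, so no step among the three can be read: the limit of > 10000 nM in this assay, at which 3 of the 3 values shown sit.

The compounds shown leave open at what concentration any of the three would show cytotoxicity, and whether the swaps on this aromatic carbon change it.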